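From 2-phenylethenyl to phenyl: estimating compound 3

The source may report more compounds than this note shows. Statements on the series, on what has been measured and on what is new or still open speak of the compounds shown alone.

Measured so far in a functional assay on MCF7 cells (Homo sapiens), tested at 2.5 uM; a lower number here means a stronger effect, a higher number a weaker effect of the compound at the concentration tested:
Compound 1 `C=CCOc1c(C)c(C)c2c(c1C)CCC(C)(COc1ccc(/C=C3\SC(=O)NC3=O)cc1)O2` gives 45%.
Compound 2 `Cc1c(C)c2c(c(C)c1OC/C=C/c1ccccc1)CCC(C)(COc1ccc(/C=C3\SC(=O)NC3=O)cc1)O2` gives 92%.

Compound 2 stands highest of the two numbers, with compound 1 its nearest neighbour, a gap well beyond the scatter. Compound 3 `Cc1c(C)c2c(c(C)c1OCc1ccccc1)CCC(C)(COc1ccc(/C=C3\SC(=O)NC3=O)cc1)O2` differs from compound 2 in one place: phenyl in place of 2-phenylethenyl on a saturated chain carbon bound to an oxygen on an aromatic ring. Among the compounds with values here, the only step touching this place is a number 47 percentage points higher from compound 1 to compound 2 (beyond the scatter), a large rise that came with the phenyl ring entering. Compound 3 keeps that phenyl but loses the double bond, so a moderate fall is expected, a number 17 percentage points lower from compound 2 to compound 3 (beyond the scatter). Compound 3 is therefore estimated at 75%, with a range from 45% to 100%.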

Compound 3, a percentage reported as activity, at one concentration (the size of the read-out at that concentration, not a potency): 85%
Compound 3: middle estimate off by 10 percentage points, on the low side; low and high end bracket the measured number.
By their numbers in this assay, from the lowest: compound 1; then compounds 3 and 2 (each within the scatter of the next).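

In this assay, going from 3-phenylprop-2-en-1-yl to benzyl gives a number 7 percentage points lower from compound 2 to compound 3 (within the scatter) and so shows that losing the double bond makes no readable difference at this position. Phenyl in place of vinyl gives a number 40 percentage points higher from compound 1 to compound 3 (beyond the scatter) and so shows that the weaker effect goes with a phenyl ring at the end of this group, with or without the double bond. No available evidence explains this link between the phenyl ring and the weaker effect. Still open, going by these compounds, is whether cyclohexyl, a non-aromatic ring, would match benzyl, and whether a simple methyl or a longer saturated chain would match compound 1.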